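A few compounds are considered here, and "the series" means these few. Any claim that something is new, unique, unknown or untested is made for them only; others in the source may bear on it.

Measured so far in a functional assay on HCT-8 cells (Homo sapiens) for cytotoxicity; a higher number here means that more compound is needed for the effect, a lower number that less compound is needed:
compound 1 `COC1=C(C)C(=O)/C(=C(O)/C=C/c2ccc(OC)cc2)C(=O)C1(C)C` gives 5.6 ug/mL
compound 2 `COC1=C(C)C(=O)/C(=C(O)/C=C/c2ccccc2OC)C(=O)C1(C)C` gives 4.1 ug/mL
compound 3 `COC1=C(C)C(=O)/C(=C(O)/C=C/c2ccccc2C)C(=O)C1(C)C` gives 4 ug/mL

Compound 3 has no separate rank, as the three values lie within the scatter of one another (a 1.4-fold lower number from compound 1 to compound 3 (0.15 log units; within the scatter); a 1.0-fold lower number from compound 2 to compound 3 (0.01 log units; within the scatter)). The next compound is compound 4 `COC1=C(C)C(=O)/C(=C(O)/C=C/c2c(C)cccc2C)C(=O)C1(C)C`, which carries methyl in place of hydrogen on an aromatic carbon, taking 2-methylphenyl to 2,6-dimethylphenyl (methyl in place of hydrogen on an aromatic carbon).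

Within the data shown here, no measured step adds a methyl in this way, so the evidence is indirect. The closest steps are the other changes on the aromatic ring (a 1.4-fold lower number from compound 1 to compound 2 (0.14 log units; within the scatter); a 1.0-fold lower number from compound 2 to compound 3 (0.01 log units; within the scatter)), and both stay within the scatter. In this assay no step beyond the scatter is therefore expected, and the data favour no direction. The expected step is small (no change at the digits printed from compound 3 to compound 4 (within the scatter)). Compound 4 is estimated at 4 ug/mL (expected range 2 ug/mL to 8 ug/mL).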

Compound 4, concentration for half-maximal effect: 7.8 ug/mL
The estimate for compound 4 lay 2.0-fold (0.29 log units) below the measured number, and the stated range covers the measured number.
By their numbers in this assay, from the lowest: compounds 3, 2, 1 and 4 (each within the scatter of the next).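

In this assay, methyl in place of hydrogen on an aromatic carbon, ortho to a large group, gives a 2.0-fold higher number from compound 3 to compound 4 (0.29 log units; within the scatter); this directly measured change to 2,6-dimethylphenyl stays within the scatter. The comparisons with the two methoxy compounds read the same way, with a 1.9-fold higher number from compound 2 to compound 4 (0.28 log units; within the scatter) and a 1.4-fold higher number from compound 1 to compound 4 (0.14 log units; within the scatter), so the four compounds still form a single group in this assay, and a ring carrying two methyl groups gives no step beyond the scatter. No measurement on these compounds offers an explanation for these steps.

The ring substituents shown are limited to methyl and methoxy, so it remains open whether this position can give a step beyond the scatter at all. An amine or a carboxylic acid on the aromatic ring would test this.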